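The source may report more compounds than this note shows. Statements on the series, on what has been measured and on what is new or still open speak of the compounds shown alone.

The measured compounds:
Compound 1 `Cc1nnc(SCc2coc3ccc(Cl)cc3c2=O)s1` gives 13400 nM in a functional assay on MCF7 cells (Homo sapiens) for cytotoxicity, read by MTT assay, with a stated time of 72 h; on this read-out lower numbers stand for stronger inhibition and higher numbers for weaker inhibition.
Compound 2 `Nc1nc(SCc2coc3ccccc3c2=O)n[nH]1` gives > 25000 nM in this assay, a limit of the assay rather than a number.
Compound 3 `Nc1nnc(SCc2coc3ccccc3c2=O)s1` gives > 25000 nM in this assay, likewise a limit of the assay.

Compound 3 thus stands at the weak end of what is shown, at the limit of > 25000 nM in this assay, at which 2 of the 3 values shown sit. Because both compounds sit at that limit, the step that the two limits leave unreadable from compound 2 to compound 3 cannot be given a size.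

Compound 4 `Cc1nnc(SCc2coc3ccccc3c2=O)s1` differs from compound 3 by methyl in place of amino on an aromatic carbon. Among the measured compounds shown here, no measured step tracks this exchange. For the measured compounds named here, the only other compound with the methyl group, compound 1, carries a chloro on the shared core and gives a readable number, 13400 nM, but the two compounds differ in more than one place, so that comparison shows only that a methyl-bearing analogue can yield a number. The step of an at least 1.2-fold lower number from compound 3 to compound 4 (0.09 log units; that floor lies within the scatter) is therefore estimated to be small and toward somewhat stronger inhibition at most. Compound 4 is expected to give about 20000 nM, within 9000 nM to 50000 nM, with a real chance that only a limit is reported again.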

Compound 4, half-maximal inhibitory concentration: 6700 nM
Estimate against measurement, compound 4: 3.0-fold (0.47 log units) above; the whole stated range lies above it.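

At this position on the five-membered ring, methyl in place of amino brings a change that can be read in this assay: the exchange gives an at least 3.7-fold lower number from compound 3 to compound 4 (0.57 log units; beyond the scatter), and a wider exchange, of the whole group on the sulfur, gives an at least 3.7-fold lower number from compound 2 to compound 4 (0.57 log units; beyond the scatter). Both steps are only floors because each starts from a limit of the assay: the limit of > 25000 nM in this assay, at which 2 of the 4 values shown sit. Hydrogen in place of chloro on an aromatic carbon gives a 2.0-fold lower number from compound 1 to compound 4 (0.30 log units; within the scatter), so a readable number with the methyl group does not depend on the chloro group on the shared core.

From the compounds shown here alone, the full size of the two floors stays open. Also open, going by these compounds, is how a longer chain such as ethyl, or a carboxylic acid, would read at this position.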